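The source may report more compounds than this note shows. Statements on the series, on what has been measured and on what is new or still open speak of the compounds shown alone.

Compound 3 `O=C1NC(=O)C2(CSC3=C2C(=O)c2ncccc2C3=O)N1` gives 3100 nM in a functional assay on SF-268 cells (Homo sapiens) for antiproliferative activity, read by MTT assay, with a stated time of 96 h (on this read-out higher numbers stand for weaker inhibition and lower numbers for stronger inhibition), the second highest of the three numbers measured. Compound 2 `O=C1NNC(=O)C2(CSC3=C2C(=O)c2ncccc2C3=O)N1` gives 4820 nM, within the scatter of compound 3, while compound 1 `CN(C)c1ccc(N2C(=O)NC3(CSC4=C3C(=O)c3ncccc3C4=O)C2=O)cc1` gives 950 nM, the lowest. Compound 4 `O=C1C2=C(C(=O)c3ncccc31)C1(CS2)NC(=O)N(c2ccccc2)C1=O` differs from compound 3 by phenyl in place of hydrogen on an amide-type nitrogen in a ring. Among the compounds with values here, the only measured step that bears on this is a 3.3-fold higher number from compound 1 to compound 3 (0.51 log units; beyond the scatter); read in reverse, placing an aryl group on that nitrogen lowered the number. Phenyl carries no dimethylamino group, so a smaller drop is expected, amounting to a 2.1-fold lower number from compound 3 to compound 4 (0.32 log units; beyond the scatter). Compound 4 is therefore estimated at 1500 nM, with a range from 600 nM to 3500 nM.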

Compound 4, half-maximal inhibitory concentration: 1700 nM
Beside the measured number, compound 4's estimate is 1.1-fold (0.05 log units) below it; low and high end bracket the measured number.
By their numbers in this assay, from the lowest: compounds 1, 4, 3 and 2 (each within the scatter of the next, the first and the last beyond it).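

Phenyl in place of hydrogen on this amide-type nitrogen gives a 1.8-fold lower number from compound 3 to compound 4 (0.26 log units; within the scatter), and hydrogen in place of dimethylamino on the aromatic carbon gives a 1.8-fold higher number from compound 1 to compound 4 (0.25 log units; within the scatter). Compound 4 thus cannot be told apart from either neighbour, although a 3.3-fold higher number from compound 1 to compound 3 (0.51 log units; beyond the scatter) is a readable step, so that step splits into two parts too small to read alone. Nothing available explains these numbers. Still open, going by these compounds, is whether a methyl group or longer chain on that nitrogen, or a methoxy group or carboxylic acid on the phenyl ring, would move the number beyond the scatter.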